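A few compounds are considered here, and "the series" means these few. Any claim that something is new, unique, unknown or untested is made for them only; others in the source may bear on it.

Three compounds sharing one core have been examined in a functional assay on a cell-free system (Platelet, plasma, Homo sapiens) for inhibition, with stated times of 1 min and 3 min; on this read-out lower numbers stand for stronger inhibition and higher numbers for weaker inhibition. For compound 1 `CCCCCCNc1nc(SCC)nc2c1ncn2[C@@H]1O[C@H](CO)[C@@H](O)[C@H]1O` the entry reads "not determined" (no result reported). Compound 2 `CCCCSc1nc(NCc2ccccc2)c2ncn([C@@H]3O[C@H](CO)[C@@H](O)[C@H]3O)c2n1` gives 202000 nM, the higher of the two numbers available, and compound 3 `CCCCSc1nc(NC2CCCCC2)c2ncn([C@@H]3O[C@H](CO)[C@@H](O)[C@H]3O)c2n1` gives 83000 nM. Within the data shown here, the only measured step, a 2.4-fold lower number from compound 2 to compound 3 (0.39 log units; beyond the scatter), is modest and puts cyclohexyl in place of benzyl on a nitrogen on an aromatic ring. Compound 4 `CCSc1nc(NCc2ccccc2)c2ncn([C@@H]3O[C@H](CO)[C@@H](O)[C@H]3O)c2n1` departs from compound 2 elsewhere: hydrogen in place of ethyl on a saturated chain carbon, two bonds along the chain from a sulfur, which turns butylsulfanyl into ethylsulfanyl. The measured step therefore concerns a different place and offers only a sense of scale. Compound 1 also carries ethylsulfanyl, but it has no number to compare. Among the measured compounds shown here, no measured step changes the chain on sulfur, so no change beyond the scatter is expected in this assay, though the uncertainty is wide in both directions. The estimated step is a 1.1-fold higher number from compound 2 to compound 4 (0.04 log units; within the scatter). The estimate for compound 4 is 220000 nM, with the result expected between 80000 nM and 500000 nM.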

Compound 4, half-maximal inhibitory concentration: 176000 nM
Beside the measured number, compound 4's estimate is 1.3-fold (0.10 log units) above it; the range from low to high includes it.
By their numbers in this assay, from the lowest: compound 3; then compounds 4 and 2 (each within the scatter of the next).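

Among these compounds, the change from butylsulfanyl to ethylsulfanyl gives a 1.1-fold lower number from compound 2 to compound 4 (0.06 log units; within the scatter) in this assay, the first reading at the chain on sulfur, and with benzyl on the nitrogen this place shows no response to the loss of ethyl. Among the compounds shown here, the only earlier step, a 2.4-fold lower number from compound 2 to compound 3 (0.39 log units; beyond the scatter), lay at the nitrogen and went beyond the scatter, so the nitrogen substituent remains the only place where the number has moved. Nothing available bears on the reason for this result.

The compounds shown leave open whether the same change would also stay within the scatter with cyclohexyl on the nitrogen. They also leave open whether a chain on sulfur ending in a carboxylic acid or an amine, or a longer chain such as octyl, would move the number.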